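A few compounds are considered here, and "the series" means these few. Any claim that something is new, unique, unknown or untested is made for them only; others in the source may bear on it.

Compound 1 `Nc1nn2c(O)cc(-c3ccc(F)cc3)nc2c1[N+](=O)[O-]`: in an ADME assay (Homo sapiens) for cytotoxicity (a lower number here means that less compound is tolerated, a higher number that more compound is tolerated), compound 1 gives > 100 ug/mL, a limit of the assay. Compound 2 `Nc1nn2c(O)cc(CCl)nc2c1[N+](=O)[O-]`: in this assay compound 2 gives > 50 ug/mL, also a limit. Compound 3 `Nc1nn2c(O)cc(CNNc3ccc(F)cc3)nc2c1[N+](=O)[O-]`: in this assay compound 3 gives > 100 ug/mL, again a limit.

Compound 3 therefore stands only at a limit, and every value shown is one: the limit of > 100 ug/mL in this assay, at which 2 of the 3 values shown sit, and (the limit of > 50 ug/mL in this assay, at which 1 of the 3 values shown sits). Among the compounds with values here, the single measured step, a step that the two limits leave unreadable from compound 1 to compound 2, has no readable size. Compound 4 `Nc1nn2c(O)cc(CNNc3ccc(S(=O)(=O)O)cc3)nc2c1[N+](=O)[O-]` differs from compound 3 by sulfo in place of fluoro on an aromatic carbon. Within the data shown here, no measured step gives a readable size in this assay, so no step beyond the scatter is expected, and compound 4 is expected to sit at the limit once more, with a number no higher from compound 3 to compound 4 (the limit leaves the size open). The estimate for compound 4 in this assay is 100 ug/mL, between 50 ug/mL and 200 ug/mL.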

Compound 4, half-maximal cytotoxic concentration: > 50 ug/mL
Compound 4 was reported as a limit; the forecaster's own chance of this, stated with the estimate: 85%; the middle value does not contradict the limit.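

Within the data shown here, compound 3 and compound 4 are both reported only as limits in this assay, so no step between them can be read. The compounds shown leave open where any true cytotoxic concentration lies, and whether sulfo in place of fluoro shifts it.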